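From methoxy to methylamino on a shared core

The source may hold more compounds than are shown below. What is called first, only, known or untested is meant among the compounds shown, and "the series" means these compounds.

In a functional assay on HCT-116 cells (Homo sapiens), read by MTT assay, with a stated time of 72 h (on this read-out lower numbers stand for stronger inhibition and higher numbers for weaker inhibition), compound 1 (`COc1ncnc2c1c(-c1ccccc1)cn2[C@@H]1O[C@H](CO)[C@@H](O)[C@H]1O`) shows > 20000 nM as its reading, which is a limit and not a number. Compound 2 (`C#Cc1cn([C@@H]2O[C@H](CO)[C@@H](O)[C@H]2O)c2ncnc(SC)c12`) gives a true number in this assay with 90 nM as its reading. Compound 3 (`CNc1ncnc2c1c(-c1ccccc1)cn2[C@@H]1O[C@H](CO)[C@@H](O)[C@H]1O`) carries methylamino in place of methoxy on an aromatic carbon. Within the data shown here, no measured pair shows this swap, so only a small gain in strength is expected in this assay, and perhaps none that the assay can register. The expected change is an at least 1.6-fold lower number from compound 1 to compound 3 (0.22 log units; that floor lies within the scatter) by this estimate. For compound 3 the estimated value is 12000 nM within an expected range from 2000 nM to 40000 nM on repeat measurement.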

Compound 3, half-maximal inhibitory concentration: > 100000 nM
Compound 3 ended at the assay's limit; the forecaster's own chance of this, stated with the estimate: 50%; middle value at least 8.3-fold (0.92 log units) away from the limit.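

Among these compounds, compound 1 and compound 3 both end at limits in this assay, so no step between them can be read. As far as these compounds go, whether methylamino in place of methoxy on the shared core changes the strength of inhibition stays open.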